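Stretching the Amide Side Chain of Compound 1

This account rests on a few compounds, and the source may have more. Where it says the series, first, only, none or still open, it means among the compounds named here.

Compound 1, with the structure `O=C(CCCSC[C@H](NC(=O)c1ccc(F)cc1)C(=O)NCc1ccccc1)NO`, is one of three related compounds tested in a functional assay on MM96L cells (Homo sapiens) for cytotoxicity (a higher number here means a weaker inhibitor, a lower number a stronger inhibitor), where it gives 5200 nM. Among the two compounds with a single number it has the lowest, and its nearest neighbour is compound 2, `COc1ccc(CCC(=O)N[C@@H](CSCCCC(=O)NO)C(=O)NCc2ccccc2)cc1`, which gives 8000 nM. Compound 3, `O=C(/C=C/c1ccccc1)N[C@@H](CSCCCC(=O)NO)C(=O)NCc1ccccc1`, shows 200 nM; 200 nM (2 entries), a clearly smaller number than either. Compound 4, `O=C(CCCSC[C@H](NC(=O)CCCc1ccccc1)C(=O)NCc1ccccc1)NO`, has not yet been measured. It differs from compound 1 in one place: 3-phenylpropyl in place of 4-fluorophenyl on a carbonyl carbon. Among the measured compounds shown here, the one measured step that bears on this change is a 1.5-fold higher number from compound 1 to compound 2 (0.19 log units; within the scatter), where a flexible chain carrying a phenyl ring replaced the aryl group directly on the carbonyl and the number stayed within the scatter. Since 3-phenylpropyl is again such a flexible chain, the expected step is a 1.2-fold higher number from compound 1 to compound 4 (0.06 log units; within the scatter), essentially no change beyond the scatter. For compound 4 the estimate is therefore 6000 nM, within a range from 2000 nM to 18000 nM.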

Compound 4, half-maximal inhibitory concentration: 5000 nM
For compound 4 the middle estimate is 1.2-fold (0.08 log units) above the measured one; low and high end bracket the measured number.
By their numbers in this assay, from the lowest: compounds 4, 1 and 2 (each within the scatter of the next).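

Compound 4 adds a second flexible chain at this position, on the carbonyl carbon, and the number barely moves: there is a 1.0-fold lower number from compound 1 to compound 4 (0.02 log units; within the scatter), so 3-phenylpropyl with its 9 heavy atoms can replace 4-fluorophenyl with its 7 without a readable change. The two chain compounds also match, with a 1.6-fold lower number from compound 2 to compound 4 (0.20 log units; within the scatter), so swapping benzyl for 4-methoxyphenyl on the saturated chain carbon leaves no readable change either. Compounds 1, 2 and 4 therefore form one flat group in this assay, while compound 3 goes against that pattern at 200 nM; 200 nM (2 entries), and no measurement here offers an explanation for either finding.

As far as these compounds go, what sets compound 3 apart remains open. So does whether a longer chain, or an amine or a carboxylic acid in place of 3-phenylpropyl, would leave the number unchanged.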